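This account rests on a few compounds, and the source may have more. Where it says the series, first, only, none or still open, it means among the compounds named here.

In a functional assay on G-361 cells (Homo sapiens) for cytotoxicity, read by MTT assay, with a stated time of 3 days (a higher number here means a weaker inhibitor, a lower number a stronger inhibitor), compound 1 `CCNc1nc(SCc2nc3ccccc3[nH]2)nc(-c2ccccc2)c1C#N` gives 4.38 nM and compound 2 `N#Cc1c(Nc2ccccn2)nc(SCc2nc3ccccc3[nH]2)nc1-c1ccccc1` gives 8.9 nM, so compound 2 has the higher, weaker number of the two. Compound 3 `CN1CCN(c2nc(SCc3nc4ccccc4[nH]3)nc(-c3ccccc3)c2C#N)CC1` keeps the shared core but carries 4-methylpiperazin-1-yl in place of (pyridin-2-yl)amino on an aromatic carbon. Going by the values given here, the only measured change at this place, pyridin-2-yl in place of ethyl, is a 2.0-fold higher number from compound 1 to compound 2 (0.31 log units; beyond the scatter), a modest step. On that single step, no shift beyond the scatter is expected, and the expected step is a 1.1-fold lower number from compound 2 to compound 3 (0.05 log units; within the scatter). The estimate for compound 3 is 8 nM, with an expected range of 2 nM to 35 nM.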

Compound 3, half-maximal inhibitory concentration: 14.7 nM
Compound 3: middle estimate off by 1.8-fold (0.26 log units), on the low side; the measured number falls inside the stated range.
By their numbers in this assay, from the lowest: compound 1; then compounds 2 and 3 (each within the scatter of the next).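

In this assay, replacing (pyridin-2-yl)amino with 4-methylpiperazin-1-yl gives a 1.7-fold higher number from compound 2 to compound 3 (0.22 log units; within the scatter), so these two compounds cannot be told apart, even though an aromatic ring with a hydrogen-bond donor has given way to a non-aromatic ring with none. Compared with the ethylamino group, the change is larger, at a 3.4-fold higher number from compound 1 to compound 3 (0.53 log units; beyond the scatter), leaving compound 1 with the lowest number of the three. How a morpholine ring, a carboxylic acid or a longer amine chain would behave at this place remains open, and nothing measured here explains these steps.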